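Phenoxy Ring Substitution and Prostacyclin Synthase Inhibition

The source may report more compounds than this note shows. Statements on the series, on what has been measured and on what is new or still open speak of the compounds shown alone.

Values in an assay for inhibition of prostacyclin synthase (Homo sapiens), using microsomes; a higher number here means a weaker inhibitor, a lower number a stronger inhibitor:
compound 1, `CC(C)(Oc1ccccc1)C1OCC(C/C=C\CCC(=O)O)C(c2cccnc2)O1`: 75000 nM
compound 2, `CC(C)(Oc1ccccc1O)C1OCC(C/C=C\CCC(=O)O)C(c2cccnc2)O1`: > 100000 nM (a limit only)
compound 3, `CC(C)(Oc1ccccc1Br)C1OCC(C/C=C\CCC(=O)O)C(c2cccnc2)O1`: 7000 nM

Compound 1 gives the highest of the two numbers; its nearest neighbour is compound 3, reached by an 11-fold lower number from compound 1 to compound 3 (1.03 log units; beyond the scatter). Compound 2 sits at the limit of > 100000 nM in this assay, at which 1 of the 3 values shown sits, a limit and not a number. Compound 4, `CC(C)(Oc1ccccc1[N+](=O)[O-])C1OCC(C/C=C\CCC(=O)O)C(c2cccnc2)O1`, differs from compound 1 by nitro in place of hydrogen on an aromatic carbon. Two steps at this place have been measured: bromo brought an 11-fold lower number from compound 1 to compound 3 (1.03 log units; beyond the scatter), whereas hydroxy gave an at least 1.3-fold higher number from compound 1 to compound 2 (0.12 log units; that floor lies within the scatter), a floor within the scatter. The nitro entry is neither, so in this assay a lower number than compound 1 is expected, but smaller than the bromo step: compound 4 is estimated at 25000 nM, between 6000 nM and 90000 nM, corresponding to an expected 3.0-fold lower number from compound 1 to compound 4 (0.48 log units; beyond the scatter).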

Compound 4, half-maximal inhibitory concentration: < 1000 nM
Compound 4 ended at the assay's limit; the forecaster's own chance of this, stated with the estimate: 10%; middle value at least 25-fold (1.39 log units) away from the limit.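

Compound 4 stands at a limit of the assay and not at a number: the limit of < 1000 nM in this assay, at which 1 of the 4 values shown sits. In this assay, a substituent at this place can do more than bromo did, since nitro gives an at least 7.0-fold lower number from compound 3 to compound 4 (0.84 log units; beyond the scatter). Against the unsubstituted ring nitro gives an at least 75-fold lower number from compound 1 to compound 4 (1.87 log units; beyond the scatter), and against hydroxy it gives an at least 100-fold lower number from compound 2 to compound 4 (2.00 log units; beyond the scatter), so the choice of group at this one place spans a wide range.

Going by these compounds, how far the true value of compound 4 lies past its limit remains open. So does how an amine or a carboxylic acid at this same place would compare with nitro.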